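The source may report more compounds than this note shows. Statements on the series, on what has been measured and on what is new or still open speak of the compounds shown alone.

Measured so far:
compound 1 `COc1ccc2oc(/C=C/c3ccc(OC(F)(F)F)cc3)cc(=O)c2c1` gives 9000 nM
compound 2 `COc1cccc2oc(/C=C/c3ccc(OC(F)(F)F)cc3)cc(=O)c12` gives 9100 nM

Both compounds were tested in a functional assay on HeLa cells (Homo sapiens) for antiproliferative activity, read by MTT assay, with a stated time of 12 h; on this read-out higher numbers stand for weaker inhibition and lower numbers for stronger inhibition. In this assay compound 1 gives 9000 nM, while compound 2 gives 9100 nM. Among the compounds with values here, compound 2 carries the higher of the two numbers, yet its only neighbour, compound 1, sits within the usual scatter of it, so the two readings cannot be told apart and neither compound can be called the stronger inhibitor.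

Compound 3 `COc1cc(OC)c2c(=O)cc(/C=C/c3ccc(OC(F)(F)F)cc3)oc2c1` has not yet been measured. It differs from compound 2 by methoxy in place of hydrogen on an aromatic carbon. Within the data shown here, no measured pair shows this particular change, so there is no step from which its effect can be read off. In this assay the change is expected to be small, in either direction, and most likely not beyond the scatter. Compound 3 is therefore expected to give about 8000 nM, with a range from 3000 nM to 25000 nM. The step of a 1.1-fold lower number from compound 2 to compound 3 (0.06 log units; within the scatter) that this estimate means is expected to stay modest.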

Compound 3, half-maximal inhibitory concentration: > 40000 nM
Compound 3 was reported as a limit (the forecaster's own chance of this, stated with the estimate: 15%); middle value at least 5.0-fold (0.69 log units) from the limit.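

In this assay, methoxy in place of hydrogen on this aromatic carbon, meta to the methoxy group already present, gives an at least 4.3-fold higher number from compound 2 to compound 3 (0.64 log units; beyond the scatter), a shift toward weaker inhibition that lies beyond the scatter. Within the data shown here, the earlier compounds offered no step at all, so this is the first sign that the shared core does not accept every change without consequence: a single added methoxy at this carbon is enough to move the reading clearly. Compound 3 gives > 40000 nM, which is a limit of the assay and not a number.

How large the step really is stays unknown, as the reading stops at that limit: the limit of > 40000 nM in this assay, at which 1 of the 3 values shown sits. Whether the weakening belongs to methoxy itself or would follow any group on this carbon also stays open, and a fluorine atom, a hydroxyl group or an amine at the same place would be needed to tell these apart, since one pair with one change gives no reason for the shift.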